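This account rests on a few compounds, and the source may have more. Where it says the series, first, only, none or still open, it means among the compounds named here.

Measured so far in an assay on isolated protein for inhibition of Amine oxidase [flavin-containing] A (Homo sapiens), read by fluorescence and Amplex Red, with a stated time of 15 min; on this read-out higher numbers stand for weaker inhibition and lower numbers for stronger inhibition:
compound 1 `C#CCN(CCC)Cc1cn(-c2cc(NC(=S)NCC)ncn2)cn1`: > 50000 nM, a limit of the assay
compound 2 `C#CCN(Cc1ccccc1)Cc1cn(-c2cc(NC(=S)NCC)ncn2)cn1`: > 50000 nM, a limit of the assay

Compound 1 stands at a limit only in this assay; no number is known for it. The step that the two limits leave unreadable from compound 1 to compound 2 cannot be read because both of its ends sit at the limit of > 50000 nM in this assay, at which 2 of the 2 values shown sit. Compound 3 `C#CCN1CCN(Cc2cn(-c3cc(NC(=S)NCC)ncn3)cn2)CC1` differs from compound 1 by a group of 9 heavy atoms (7 carbon, 2 nitrogen; one six-membered non-aromatic ring with 2 hetero atoms) in place of a group of 7 heavy atoms (6 carbon, 1 nitrogen; no ring), on a saturated chain carbon bound to an aromatic carbon; the 4-propargylpiperazin-1-yl group enters where the open chain left. No measured step bears on this exchange: the single step shown, from compound 1 to compound 2, is unreadable, and both measured compounds rest at the limit. No direction or size for the step in this assay can therefore be drawn from the numbers shown. With both measured compounds at the limit, compound 3 is expected to sit around 100000 nM, from 20000 nM to 500000 nM, most likely reported again as a limit. This corresponds to an expected step that the limit leaves unreadable from compound 1 to compound 3.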

Compound 3, half-maximal inhibitory concentration: > 50000 nM
Compound 3: no number, only a limit; the forecaster's own chance of this, stated with the estimate: 80%; the middle value lies beyond the limit too.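

In this assay compound 3 gives > 50000 nM, a limit of the assay, and compound 1 likewise gives no number, so no new step can be read. The compounds shown leave open whether any exchange on the shared core changes inhibition, as all values rest at one limit: the limit of > 50000 nM in this assay, at which 3 of the 3 values shown sit.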